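Adding a methylsulfonyl group to the benzamide of compound 3

The source may hold more compounds than are shown below. What is called first, only, known or untested is meant among the compounds shown, and "the series" means these compounds.

Measured so far:
Compound 1, `Cc1ccc(C(=O)Nc2ccc(Cl)c(-c3ccccn3)c2)c(C)n1`, gives 130 nM in an assay on C3H 10T1/2 cells for inhibition of Sonic hedgehog protein (Mus musculus), read by a luciferase reporter; a lower number here means a stronger inhibitor, a higher number a weaker inhibitor.
Compound 2, `O=C(Nc1ccc(Cl)c(-c2ccccn2)c1)c1ccncc1`, gives 700 nM.
Compound 3, `O=C(Nc1ccc(Cl)c(-c2ccccn2)c1)c1ccccc1`, gives 800 nM.

Compound 3 has the highest number of the three, but its gap to compound 2 is small: a 1.1-fold higher number from compound 2 to compound 3 (0.06 log units; within the scatter). Its gap to compound 1 is larger: a 6.2-fold higher number from compound 1 to compound 3 (0.79 log units; beyond the scatter). Compound 4, `CS(=O)(=O)c1cccc(C(=O)Nc2ccc(Cl)c(-c3ccccn3)c2)c1`, changes compound 3 in one place: methylsulfonyl in place of hydrogen on an aromatic carbon. The change sits on an aromatic carbon of a six-membered aromatic ring of carbon only, meta to a large group.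

Going by the values given here, none of the measured steps tests this exact change. The steps that touch the same ring are a 5.4-fold higher number from compound 1 to compound 2 (0.73 log units; beyond the scatter) and a 6.2-fold higher number from compound 1 to compound 3 (0.79 log units; beyond the scatter), both modest, while a 1.1-fold higher number from compound 2 to compound 3 (0.06 log units; within the scatter) lies within the scatter. Swapping one unsubstituted ring for another therefore changed little, and a single added group is expected to move the number only modestly, with no clear direction. The expected step is no change at the digits printed from compound 3 to compound 4 (within the scatter). Compound 4 is estimated at 800 nM, with a range from 250 nM to 2500 nM.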

Compound 4, half-maximal inhibitory concentration: 120 nM
The estimate for compound 4 lay 6.7-fold (0.82 log units) above the measured number, outside the stated range (below it).
By their numbers in this assay, from the lowest: compounds 4 and 1 (each within the scatter of the next); then compounds 2 and 3 (each within the scatter of the next).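

In this assay, methylsulfonyl in place of hydrogen gives a 6.7-fold lower number from compound 3 to compound 4 (0.82 log units; beyond the scatter) and is beyond the scatter, so this aromatic carbon, meta to a large group, accepts a substituent and the number responds to it. The earlier step between two unsubstituted rings, a 1.1-fold higher number from compound 2 to compound 3 (0.06 log units; within the scatter) and so within the scatter, gave no sign of this. A single group added to the phenyl ring can therefore matter where that swap of one ring for another did not. Nothing available here explains why the number falls with this group.

Open, from the compounds shown here alone, is whether a smaller group such as methyl or nitrile, or a carboxylic acid or an amine, would act alike on this carbon. Also open, going by these compounds, is whether methylsulfonyl would give a similar step on another carbon of the ring.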